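This account rests on a few compounds, and the source may have more. Where it says the series, first, only, none or still open, it means among the compounds named here.

Measured in a physicochemical assay for solubility, read by nephelometry, measured as kinetic solubility, with a stated time of 30 min; a higher number here means a more soluble compound, a lower number a less soluble compound:
- compound 1 `c1cc([C@H]2CC[C@]3(CC2)OOC2(O3)C3CC4CC(C3)CC2C4)ccc1OCCC1CCNCC1`: > 100 ug/mL, a limit
- compound 2 `c1cc([C@H]2CC[C@]3(CC2)OOC2(O3)C3CC4CC(C3)CC2C4)ccc1OC1CCNCC1`: > 100 ug/mL, a limit
- compound 3 `c1cc([C@H]2CC[C@]3(CC2)OOC2(O3)C3CC4CC(C3)CC2C4)ccc1OCC1CCNCC1`: 12.5 ug/mL

Of the three, compound 3 alone has an actual number, 12.5 ug/mL. The rest of the set stands at the limit of > 100 ug/mL in this assay, at which 2 of the 3 values shown sit.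

Compound 4 `CC1(C)CC(O)(COc2ccc([C@H]3CC[C@]4(CC3)OOC3(O4)C4CC5CC(C4)CC3C5)cc2)CC(C)(C)N1` differs from compound 3 as follows: 4-hydroxy-2,2,6,6-tetramethylpiperidin-4-yl in place of piperidin-4-yl on a saturated chain carbon bound to an oxygen on an aromatic ring. This places 4-hydroxy-2,2,6,6-tetramethylpiperidin-4-yl in place of piperidin-4-yl on a saturated chain carbon bound to an oxygen on an aromatic ring.

Going by the values given here, three measured steps touch this part of the series. Two have a readable lower bound: an at least 8.0-fold lower number from compound 1 to compound 3 (0.90 log units; beyond the scatter) and an at least 8.0-fold lower number from compound 2 to compound 3 (0.90 log units; beyond the scatter). The third is a step that the two limits leave unreadable from compound 1 to compound 2. All three change the link to the piperidine, and none carries the groups entering here, so they set no direction for this change. Only a modest move in this assay is therefore expected. The estimated step is a 1.6-fold higher number from compound 3 to compound 4 (0.20 log units; within the scatter). For compound 4 the expected value is 20 ug/mL, with an estimated range from 5 ug/mL to 100 ug/mL.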

Compound 4, solubility: > 100 ug/mL
Compound 4 was reported as a limit (the forecaster's own chance of this, stated with the estimate: 20%); at least 5.0-fold (0.69 log units) between middle value and limit.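

The step of an at least 8.0-fold higher number from compound 3 to compound 4 (0.90 log units; beyond the scatter) in this assay keeps the link to the oxygen on the aromatic ring and changes only the ring group, whereas the three earlier steps all changed the link to the piperidine. Compound 4 gives > 100 ug/mL, a limit, and joins the other compounds that sit at it: the limit of > 100 ug/mL in this assay, at which 3 of the 4 values shown sit.
The steps to compound 4 from compound 1 and from compound 2 cannot be read, as both ends of each are limits.

As far as these compounds go, the 4-hydroxy and the four methyl groups enter together, so their separate shares in the step stay open; a 4-hydroxypiperidin-4-yl group or a 2,2,6,6-tetramethylpiperidin-4-yl group at the same place would separate them. From the compounds shown here alone, the order among compound 1, compound 2 and compound 4 also stays open.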